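A few compounds are considered here, and "the series" means these few. Any claim that something is new, unique, unknown or untested is made for them only; others in the source may bear on it.

Measured in a functional assay on MCF7 cells (Homo sapiens) for antiproliferative activity, read by sulforhodamine B assay, with a stated time of 3 days; on this read-out higher numbers stand for weaker inhibition and lower numbers for stronger inhibition:
- compound 1 `c1ccc(Sc2ncnc3c2ncn3C2COc3ccccc3CO2)cc1`: 7120 nM
- compound 2 `c1ccc(Oc2ncnc3ncn(C4COc5ccccc5CO4)c23)cc1`: 21100 nM

Of these two, compound 2 has the higher number at 21100 nM, and so the weaker inhibition in this assay. Compound 1 stands lower at 7120 nM, a gap beyond the scatter.

The next compound to be tested is compound 3 `CSc1ncnc2ncn(C3COc4ccccc4CO3)c12`, which carries methylsulfanyl in place of phenoxy on an aromatic carbon. Going by the values given here, no measured pair shows this change on its own, so the expectation is loose. It starts from compound 2 at 21100 nM and leans slightly towards the lower number of compound 1 at 7120 nM. In this assay, no step beyond the scatter is expected. The estimated step is a 1.5-fold lower number from compound 2 to compound 3 (0.18 log units; within the scatter). For compound 3 the expected value is 14000 nM, with an estimated range of 5000 nM to 40000 nM.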

Compound 3, half-maximal inhibitory concentration: 31800 nM
The estimate for compound 3 lay 2.3-fold (0.36 log units) below the measured number, within the range that was stated.
By their numbers in this assay, from the lowest: compound 1; then compounds 2 and 3 (each within the scatter of the next).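

In this assay, methylsulfanyl in place of phenoxy on this aromatic carbon, next to the ring nitrogen, gives a 1.5-fold higher number from compound 2 to compound 3 (0.18 log units; within the scatter). The six-membered aromatic ring of phenoxy can therefore be lost at this position without a step beyond the scatter, and compound 3 stands at 31800 nM, while compound 1 keeps the lowest printed number at 7120 nM. Nothing available explains why these two groups read alike here.

The compounds shown leave open whether any group at this position would bring the number well below those seen so far. An amine, such as morpholine, or a longer chain on sulfur, such as butylsulfanyl, would show whether this position tolerates other groups as well, or whether the number moves with what is attached there.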